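Removing the halogens and lengthening the linker in a quinoline series

The source may hold more compounds than are shown below. What is called first, only, known or untested is meant among the compounds shown, and "the series" means these compounds.

Measured compounds:
Compound 1, `COc1cccc(CNCCCNc2ccnc3cc(-c4ccccc4)ccc23)c1O`: 3210 nM
Compound 2, `COc1cccc(CNCCCNc2ccnc3cc(CC4CCCCC4)ccc23)c1O`: 970 nM
Compound 3, `COc1cccc(CNCCCNc2ccnc3cc(Cc4ccc(F)cc4Cl)ccc23)c1O`: 2350 nM

In an ADME assay on HepG2 cells (Homo sapiens) for cytotoxicity, read by luminescence, CellTiter-Glo and ATP content, with a stated time of 72 h (on this read-out higher numbers stand for an effect only at larger amounts of compound and lower numbers for an effect already at smaller amounts), compound 3 gives 2350 nM. Its number lies close to that of compound 1, a gap within the scatter, while against compound 2 it stands apart, as the step of a 2.4-fold higher number from compound 2 to compound 3 (0.38 log units; beyond the scatter) shows, which is beyond the scatter.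

Compound 4, `COc1cccc(CNCCCNc2ccnc3cc(CCc4ccccc4)ccc23)c1O`, has not yet been measured. It differs from compound 3 by benzyl in place of 2-chloro-4-fluorophenyl on a saturated chain carbon bound to an aromatic carbon.

Within the data shown here, two measured steps touch the same position. The step of a 1.4-fold lower number from compound 1 to compound 3 (0.14 log units; within the scatter) was within the scatter, and the step of a 2.4-fold higher number from compound 2 to compound 3 (0.38 log units; beyond the scatter) was modest. Among the measured compounds shown here, neither step removes the chlorine and fluorine or lengthens the chain at once, so no close precedent exists. As compounds 1 and 3 sit within the scatter of each other and only the cyclohexylmethyl of compound 2 stands apart, the expectation for compound 4 is a step in this assay of a 1.2-fold lower number from compound 3 to compound 4 (0.07 log units; within the scatter), not beyond the scatter, with a slight lean toward a lower number.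

Compound 4 is therefore estimated at 2000 nM in this assay, with a range from 900 nM to 4500 nM.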

Compound 4, half-maximal effective concentration: 6800 nM
The estimate for compound 4 lay 3.4-fold (0.53 log units) below the measured number, and the stated range ends below it.
By their numbers in this assay, from the lowest: compound 2; then compounds 3 and 1 (each within the scatter of the next); then compound 4.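

In this assay the phenethyl of compound 4 gives the highest number of the four, with a 2.9-fold higher number from compound 3 to compound 4 (0.46 log units; beyond the scatter) and a 2.1-fold higher number from compound 1 to compound 4 (0.33 log units; beyond the scatter) as its steps against the two compounds that had stood within the scatter of each other. Until now, the only departure at this position was the lower number of the cyclohexylmethyl group, and a 7.0-fold higher number from compound 2 to compound 4 (0.85 log units; beyond the scatter) shows that the groups placed here can also separate in the upward direction, widening the span seen at this position. Nothing measured here accounts for the rise in the number.

The step from compound 3 changes two things at once, as it removes the chlorine and fluorine and also lengthens the chain, so the part played by each remains unresolved; a 2-chloro-4-fluorophenethyl group or an unsubstituted benzyl group on the same carbon would separate them. From the compounds shown here alone, it also remains open whether a longer chain, such as 3-phenylpropyl, would carry the number further up, and whether 2-cyclohexylethyl would follow phenethyl or stay with cyclohexylmethyl.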